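This account rests on a few compounds, and the source may have more. Where it says the series, first, only, none or still open, it means among the compounds named here.

Measured so far in a functional assay on HCT-116 cells (Homo sapiens) for inhibition, read by sulforhodamine B assay, with a stated time of 72 h; on this read-out higher numbers stand for weaker inhibition and lower numbers for stronger inhibition:
compound 1 `COc1ccc2cc(C(C)c3nnc4n3N=C(c3ccc(F)cc3)CS4)ccc2c1`: 13100 nM
compound 2 `CC(c1ccc(-c2ccccc2)c(F)c1)c1nnc2n1N=C(c1ccc(Cl)cc1)CS2`: 7800 nM

Compound 1 carries the larger of the two numbers, but its gap to compound 2 lies within the scatter, so the two cannot be told apart in this assay. Compound 3 `COc1ccc2cc(C(C)c3nnc4n3N=C(c3ccc(C)cc3)CS4)ccc2c1` is not yet measured. It differs from compound 1 by methyl in place of fluoro on an aromatic carbon. Among the measured compounds shown here, no measured pair shows this change, so no direction can be read off; the change is expected to shift the number by no more than the scatter, a 1.2-fold lower number from compound 1 to compound 3 (0.08 log units; within the scatter). Compound 3 is accordingly estimated at 11000 nM, within 4000 nM to 30000 nM.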

Compound 3, half-maximal inhibitory concentration: 10200 nM
Compound 3: the middle estimate sits 1.1-fold (0.03 log units) above what was measured, within the range that was stated.
By their numbers in this assay, from the lowest: compounds 2, 3 and 1 (each within the scatter of the next).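

Methyl in place of fluoro, para to a large group, gives the first one-place comparison in the series: in this assay it reads a 1.3-fold lower number from compound 1 to compound 3 (0.11 log units; within the scatter) and so lies within the scatter. At this position, the 4-fluorophenyl and 4-methylphenyl compounds cannot be told apart. No available evidence bears on this result.

As far as these compounds go, it remains open whether an amine, a carboxylic acid or a longer chain at this position would give a number beyond the scatter. Among the compounds shown here, the one pair also leaves open whether methyl in place of fluoro would read the same on another core.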